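Swapping One Pyridinyl Group for Another

This account rests on a few compounds, and the source may have more. Where it says the series, first, only, none or still open, it means among the compounds named here.

Measured in a physicochemical assay for lipophilicity; a lower number here means a more polar compound, a higher number a more lipophilic compound:
- Compound 1 `Cc1nc(C#Cc2ccccc2)cs1` gives 3.3
- Compound 2 `Cc1nc(C#Cc2cncc(-c3ccccc3)c2)cs1` gives 4.1
- Compound 3 `Cc1nc(C#Cc2cncc(-c3cccnc3)c2)cs1` gives 2.4

Compound 3 has the lowest number of the three, and its gaps to compound 1 and compound 2 both lie beyond the scatter. The next compound, compound 4 `Cc1nc(C#Cc2cncc(-c3ccncc3)c2)cs1`, has the same atoms joined differently: pyridin-4-yl in place of pyridin-3-yl on an aromatic carbon.

Going by the values given here, only one measured step bears on this change. It is large: a number 1.70 log units lower from compound 2 to compound 3 (beyond the scatter), with pyridin-3-yl in place of phenyl. That step changed the atoms, whereas this one does not, so its size should not simply carry over. Among the compounds with values here, no measured step swaps one pyridinyl group for another, which leaves the guide indirect. Going by these compounds, no step beyond the scatter is expected, so the direction stays open. The expected change is no change at the digits printed from compound 3 to compound 4 (within the scatter). The estimated value for compound 4 is 2.4, with an expected range from 2 to 2.8.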

Compound 4, distribution coefficient: 2.6
For compound 4 the middle estimate is 0.20 log units below the measured one; low and high end bracket the measured number.
By their numbers in this assay, from the lowest: compounds 3 and 4 (each within the scatter of the next); then compound 1; then compound 2.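

Exchanging pyridin-3-yl for pyridin-4-yl on this aromatic carbon gives a number 0.20 log units higher from compound 3 to compound 4 (within the scatter) in this assay and so does not separate the two groups at this position. Pyridin-4-yl in place of phenyl gives a number 1.50 log units lower from compound 2 to compound 4 (beyond the scatter) and shows that the large fall seen earlier is not confined to pyridin-3-yl: both pyridinyl groups shown lie well under the phenyl compound, although the ring nitrogen stands at a different place in each. Nothing at hand explains why these two groups give numbers within the scatter of each other.

Going by these compounds, whether pyridin-2-yl would stay with these two groups or part from them remains open. So does what an amine or a carboxylic acid on this same carbon would do to the number in this assay in place of either pyridinyl group.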